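The source may report more compounds than this note shows. Statements on the series, on what has been measured and on what is new or still open speak of the compounds shown alone.

Measured so far in a functional assay on HCT-116 cells (Homo sapiens) for inhibition, read by MTT assay, with a stated time of 48 h; on this read-out lower numbers stand for stronger inhibition and higher numbers for weaker inhibition
- Compound 1 `COc1ccc(-n2c(SCc3ccc(F)cc3)nnc2-c2cc(OC)c(OC)c(OC)c2)cc1` gives 38700 nM
- Compound 2 `COc1cc(-c2nnc(SCc3ccccc3)n2-c2ccc(N(C)C)cc2)cc(OC)c1OC` gives 54000 nM
- Compound 3 `COc1cc(-c2nnc(SCc3ccc(F)cc3)n2-c2ccc(N(C)C)cc2)cc(OC)c1OC` gives > 60000 nM (a limit, not a number)

Compound 3 stands at the limit of > 60000 nM in this assay, at which 1 of the 3 values shown sits. In compound 4 `COc1cc(-c2nnc(SCC(=O)c3ccc4ccccc4c3)n2-c2ccc(N(C)C)cc2)cc(OC)c1OC`, (naphthalen-2-yl)carbonyl replaces 4-fluorophenyl on a saturated chain carbon bound to a sulfur ((naphthalen-2-yl)carbonyl in place of 4-fluorophenyl on a saturated chain carbon bound to a sulfur). Among the measured compounds shown here, two measured steps touch compound 3, both with floors within the scatter: an at least 1.1-fold higher number from compound 2 to compound 3 (0.04 log units; that floor lies within the scatter) for fluoro in place of hydrogen, and an at least 1.5-fold higher number from compound 1 to compound 3 (0.19 log units; that floor lies within the scatter) for dimethylamino in place of methoxy. Neither tests the entering group, so they give little guide to size. For compound 3, > 60000 nM is a limit and not a number. The expected step is an at least 10-fold lower number from compound 3 to compound 4 (1.00 log units; beyond the scatter), toward a lower number in this assay, with wide uncertainty. For compound 4 the estimate is 6000 nM, with an expected range of 300 nM to 50000 nM.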

Compound 4, half-maximal inhibitory concentration: 54500 nM
Estimate against measurement, compound 4: 9.1-fold (0.96 log units) below; measured number outside the range, above it.
By their numbers in this assay, from the lowest: compounds 1, 2 and 4 (each within the scatter of the next). At a limit, above all of these: compound 3.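

In this assay, (naphthalen-2-yl)carbonyl in place of phenyl on a saturated chain carbon bound to a sulfur gives a 1.0-fold higher number from compound 2 to compound 4 (0.00 log units; within the scatter), so adding a carbonyl and a second aromatic ring at this position produces no readable shift. Against 4-fluorophenyl, the same group gives an at least 1.1-fold lower number from compound 3 to compound 4 (0.04 log units; that floor lies within the scatter). Compound 3 remains a limit, not a number: the limit of > 60000 nM in this assay, at which 1 of the 4 values shown sits.

Among the compounds shown here, no step at this position lies beyond the scatter. Open, going by these compounds, is whether a different group on this chain, such as an amine or a carboxylic acid, would move the number in this assay.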